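A few compounds are considered here, and "the series" means these few. Any claim that something is new, unique, unknown or untested is made for them only; others in the source may bear on it.

In a functional assay on MCF7 cells (Homo sapiens) for antiproliferative activity, read by MTT assay, with a stated time of 72 h (a lower number here means a stronger inhibitor, a higher number a weaker inhibitor), compound 2 `C=CC(=O)Nc1cccc(Oc2nc(Nc3cccc(C#N)c3)nc3c2CSCC3)c1` gives 21700 nM and compound 3 `CC/C=C/C(=O)Nc1cccc(Oc2nc(Nc3cccc(C#N)c3)nc3c2CSCC3)c1` gives 15900 nM. These two values lie within the scatter of each other, so repeat measurements could not reliably tell them apart. Compound 1 `CC(C)=CC(=O)Nc1cccc(Oc2nc(Nc3ccn(C)n3)nc3c2CSCC3)c1` reads > 50000 nM, and this is a limit of the assay, not a number. Compound 3 therefore has one numerical neighbour, compound 2, and the two stand level within the scatter.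

Compound 4 `CC(C)=CC(=O)Nc1cccc(Oc2nc(Nc3cccc(C#N)c3)nc3c2CSCC3)c1` keeps the rest of compound 3 and changes a single group, with 2-methylprop-1-en-1-yl in place of but-1-en-1-yl on a carbonyl carbon. The two groups hold the same atoms, joined differently.

Among the compounds with values here, one measured step bears on this change, since it alters the group at the same carbonyl carbon. That step, a 1.4-fold lower number from compound 2 to compound 3 (0.14 log units; within the scatter), put but-1-en-1-yl in place of vinyl and stayed within the scatter. Within the data shown here, with only this small step as a guide, no shift beyond the scatter is expected in this assay, and the direction remains open. The expected step is a 1.2-fold higher number from compound 3 to compound 4 (0.08 log units; within the scatter), which is a modest estimate resting on very little data. Compound 4 is expected to read about 19000 nM, within an estimated range of 9000 nM to 42000 nM.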

Compound 4, half-maximal inhibitory concentration: > 50000 nM
Compound 4 gave a limit, no number; the forecaster's own chance of this, stated with the estimate: 15%; middle value at least 2.6-fold (0.42 log units) from the limit.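

Up to this point, the only readable change at this carbonyl carbon had stayed within the scatter, but in this assay simply rejoining the same atoms gives an at least 3.1-fold higher number from compound 3 to compound 4 (0.49 log units; beyond the scatter). Set against the smaller vinyl group, 2-methylprop-1-en-1-yl gives an at least 2.3-fold higher number from compound 2 to compound 4 (0.36 log units; beyond the scatter), so with 3-cyanophenyl held on the nitrogen, this group reads apart from both but-1-en-1-yl and vinyl, and the place is shown to respond to how the chain is joined and not only to what it contains. The two steps give only a minimum size, and the step between compound 1 and compound 4 cannot be read, because these readings are limits and not numbers: the limit of > 50000 nM in this assay, at which 2 of the 4 values shown sit.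

From the compounds shown here alone, how a prop-1-en-1-yl group, a saturated 2-methylpropyl group or a chain carrying an amine would read at this carbonyl carbon stays open. Also open, going by these compounds, is whether 3-cyanophenyl and 1-methyl-1H-pyrazol-3-yl on the nitrogen would differ at all with vinyl or but-1-en-1-yl on the carbonyl carbon.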